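The source may hold more compounds than are shown below. What is called first, only, known or untested is meant among the compounds shown, and "the series" means these compounds.

In a functional assay on MCF7 cells (Homo sapiens) for cytotoxicity, read by MTT assay, with a stated time of 24 h, tested at 6.4 ug/mL (on this read-out higher numbers stand for a stronger effect at the one concentration tested and lower numbers for a weaker effect), compound 3 `Cn1c(-c2ccc(NC(=O)CN3CCN(Cc4ccccc4)CC3)cc2)nc(-c2ccccc2)c1-c1ccccc1` gives 23.8%. Compound 1 `CN1CCN(CC(=O)Nc2ccc(-c3nc(-c4ccccc4)c(-c4ccccc4)n3C)cc2)CC1` gives 28.6%, and the gap a number 4.8 percentage points lower from compound 1 to compound 3 (within the scatter) stays within the scatter. Compound 2 `CN(C)/C=C/N1CCN(CC(=O)Nc2ccc(-c3nc(-c4ccccc4)c(-c4ccccc4)n3C)cc2)CC1` gives 11.1%. The step of a number 12.7 percentage points higher from compound 2 to compound 3 (beyond the scatter) is beyond the scatter, as is a number 17.5 percentage points lower from compound 1 to compound 2 (beyond the scatter). Compound 3 thus sits second of the three numbers, close to compound 1 and apart from compound 2. Compound 4 `Cc1ccc(CN2CCN(CC(=O)Nc3ccc(-c4nc(-c5ccccc5)c(-c5ccccc5)n4C)cc3)CC2)cc1` differs from compound 3 by methyl in place of hydrogen on an aromatic carbon. For the measured compounds named here, no measured step touches an aromatic carbon of this benzyl; the steps that bear on it, a number 4.8 percentage points lower from compound 1 to compound 3 (within the scatter) and a number 12.7 percentage points higher from compound 2 to compound 3 (beyond the scatter), both concern a change on an amine nitrogen in a ring. A step in this assay of no size beyond the scatter is therefore expected, a number 0.2 percentage points higher from compound 3 to compound 4 (within the scatter). Compound 4 is estimated at 24%, with a range of 10% to 38%.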

Compound 4, a percentage reported as activity, at one concentration (the size of the read-out at that concentration, not a potency): 21.8%
The estimate for compound 4 lay 2.2 percentage points above the measured number, and the stated range covers the measured number.
By their numbers in this assay, from the lowest: compound 2; then compounds 4, 3 and 1 (each within the scatter of the next).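

In this assay, methyl on an aromatic carbon of the benzyl, para to a large group, is the first change shown on this ring, and the step of a number 2 percentage points lower from compound 3 to compound 4 (within the scatter) stays within the scatter. 4-Methylbenzyl on the ring amine nitrogen reads like benzyl against the other two compounds, with a number 6.8 percentage points lower from compound 1 to compound 4 (within the scatter) and a number 10.7 percentage points higher from compound 2 to compound 4 (beyond the scatter) as the steps. Nothing measured here gives a reason for these numbers. Still open, as far as these compounds go, is whether an amine or a carboxylic acid at this same ring carbon, or a longer chain in place of methyl, would give a step beyond the scatter.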